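The compounds below may be only part of what the source reports. "The series", "measured", "known", "first", "only" and "open" are said of these compounds alone.

Measured so far:
- compound 1, `Cc1ccc(C)c(NC(=O)Nc2nc(Sc3c[nH]c4ccccc34)cc(N3CCCCC3)n2)c1`, in a functional assay on MDA-MB-231 cells (Homo sapiens) for inhibition, with a stated time of 72 h (on this read-out lower numbers stand for stronger inhibition and higher numbers for weaker inhibition), gives 5940 nM
- compound 2, `O=C(Nc1ccccc1)Nc1nc(NC2CC2)cc(Sc2c[nH]c3ccccc23)n1`, in this assay gives 7860 nM
- compound 3, `O=C(Nc1ccccc1)Nc1nc(Sc2c[nH]c3ccccc23)cc(N2CCN(Cc3ccccc3)CC2)n1`, in this assay gives 10200 nM

The three measured compounds share one core and differ only in the group on the second ring nitrogen. Their half-maximal inhibitory concentrations in this assay lie close together: compound 2 stands second highest of the three numbers, nearest to compound 3 and furthest from compound 1, but both of those gaps fall within the scatter of repeated measurements, so no order among the three can be read from the values.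

Compound 4, `O=C(Nc1ccccc1)Nc1nc(Nc2ccccc2)cc(Sc2c[nH]c3ccccc23)n1`, has not yet been measured. It differs from compound 2 by phenyl in place of cyclopropyl on a nitrogen on an aromatic ring, that is, cyclopropylamino becomes anilino. Within the data shown here, no measured pair in this set isolates that change. Given that the three measured substituents at this position all give numbers within the scatter of one another, the step from compound 2 to compound 4 is expected to be small, a 1.2-fold lower number from compound 2 to compound 4 (0.08 log units; within the scatter), with no direction beyond the scatter. The value for compound 4 in this assay is estimated at 6500 nM, within a range from 2200 nM to 19000 nM.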

Compound 4, half-maximal inhibitory concentration: 35900 nM
Compound 4: middle estimate off by 5.5-fold (0.74 log units), on the low side, outside the stated range (above it).
By their numbers in this assay, from the lowest: compounds 1, 2 and 3 (each within the scatter of the next); then compound 4.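

In this assay, among these compounds, the change from cyclopropylamino to anilino gives a 4.6-fold higher number from compound 2 to compound 4 (0.66 log units; beyond the scatter) and is the first step that lies beyond the scatter. The group on this nitrogen on an aromatic ring can therefore shift the read-out, which the closely grouped earlier values did not show. The step is modest and rests on this single pair, so it marks phenyl as less favourable than cyclopropyl here but defines no wider trend. No measurement available here accounts for the step.

Going by these compounds, it remains open whether the loss belongs to phenyl alone or extends to benzyl, pyridyl or methoxyphenyl on this nitrogen. Also open, on these data alone, is how small open-chain groups such as methyl or 2-hydroxyethyl on this nitrogen compare with cyclopropyl.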